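This account rests on a few compounds, and the source may have more. Where it says the series, first, only, none or still open, it means among the compounds named here.

Compound 2 `COc1ccc(C(=O)Nc2cccc(-c3oc4cc(-c5ccc(F)cc5)ccc4c(=O)c3O)c2)c(F)c1` shows the highest number among the two compounds measured in a functional assay on A549 cells (Homo sapiens) for antiproliferative activity, read by CCK-8 assay, with a stated time of 72 h; a lower number here means a stronger inhibitor, a higher number a weaker inhibitor: compound 2 gives 40000 nM. Among the measured compounds shown here, its nearest neighbour, compound 1 `O=C(Nc1cccc(-c2oc3cc(-c4ccc(F)cc4)ccc3c(=O)c2O)c1)c1ccc(Br)cc1`, gives 13500 nM; the only measured step, a 3.0-fold higher number from compound 1 to compound 2 (0.47 log units; beyond the scatter), exchanged one aryl group on the carbonyl carbon for another. Compound 3 `O=C(Nc1cccc(-c2oc3cc(-c4ccc(F)cc4)ccc3c(=O)c2O)c1)c1ccc(Cl)nc1` differs from compound 2 in the same place: 6-chloropyridin-3-yl in place of 2-fluoro-4-methoxyphenyl on a carbonyl carbon. Because that single step a 3.0-fold higher number from compound 1 to compound 2 (0.47 log units; beyond the scatter) was modest, and because the entering group carries a halogen as the group in compound 1 does, the step from compound 2 is expected to be modest and to move back toward a lower number, but with wide uncertainty. For compound 3 the expected step is a 2.0-fold lower number from compound 2 to compound 3 (0.30 log units; within the scatter). Compound 3 is therefore estimated to reach about 20000 nM in this assay, within a range from 7000 nM to 60000 nM.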

Compound 3, half-maximal inhibitory concentration: 3580 nM
Estimate against measurement, compound 3: 5.6-fold (0.75 log units) above; measured number outside the range, below it.
By their numbers in this assay, from the lowest: compound 3; then compound 1; then compound 2.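

In this assay, among the compounds shown here, the choice of aryl group on the carbonyl carbon matters more than the first pair suggested: an 11-fold lower number from compound 2 to compound 3 (1.05 log units; beyond the scatter) is a large step, whereas the only earlier step was modest. The 6-chloropyridin-3-yl group also outdoes the 4-bromophenyl group, with a 3.8-fold lower number from compound 1 to compound 3 (0.58 log units; beyond the scatter), so its advantage is not merely a matter of replacing the 2-fluoro-4-methoxyphenyl group. Nothing shown here explains this order among the three compounds.

The compounds shown leave open whether the ring nitrogen, the chlorine or the two together account for the lower number, as compound 3 is the only one here with a ring hetero atom. A plain pyridin-3-yl group, a 4-chlorophenyl group or a 6-aminopyridin-3-yl group on the same carbonyl carbon would help to separate these contributions.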